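A few compounds are considered here, and "the series" means these few. Any claim that something is new, unique, unknown or untested is made for them only; others in the source may bear on it.

Three carbamates sharing one core have been tested in a functional assay on CHO cells for antagonist activity at metabotropic glutamate receptor 5 (Homo sapiens), read by calcium flux; on this read-out higher numbers stand for weaker inhibition and lower numbers for stronger inhibition. Compound 1 `Cc1c(C(C)OC(=O)Nc2ccc(Cl)cc2)oc2ncnn12` gives 2510 nM. Compound 2 `Cc1c(C(C)OC(=O)Nc2ccc(Cl)c(Cl)c2)oc2ncnn12`, which carries a second chloro on its phenyl ring, gives 5010 nM; the change from compound 1 to compound 2 amounts to a 2.0-fold higher number from compound 1 to compound 2 (0.30 log units; within the scatter). Compound 3 `Cc1c(C(C)OC(=O)Nc2ccccc2)oc2nc(Cl)nn12`, in which the phenyl ring of the carbamate bears no substituent and a chloro sits instead on the core, gives 10 nM, the lowest number of the three, and its distance from the numbers of compound 1 and compound 2 is far beyond the scatter.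

Compound 4 `Cc1c(C(C)OC(=O)Nc2ccccc2)oc2nc(-c3ccc(F)cc3)nn12` is compound 3 with a single change: 4-fluorophenyl in place of chloro on an aromatic carbon. Going by the values given here, no measured pair tests this kind of change. Among the compounds with values here, the only single-place step on record, from compound 1 to compound 2, concerns the phenyl ring of the carbamate, not the core, and compound 1 and compound 3 differ in two places at once, so neither tells how the core tolerates a larger group at that carbon. The expectation for compound 4 therefore rests mainly on the strong number of compound 3 and is uncertain. Compound 4 is estimated at 30 nM, with a range from 4 nM to 250 nM, which would mean an expected step of a 3.0-fold higher number from compound 3 to compound 4 (0.48 log units; beyond the scatter).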

Compound 4, half-maximal inhibitory concentration: 10 nM
For compound 4 the middle estimate is 3.0-fold (0.48 log units) above the measured one; measured number inside the range.
By their numbers in this assay, from the lowest: compounds 3 and 4 (each within the scatter of the next); then compounds 1 and 2 (each within the scatter of the next).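

Replacing chloro with 4-fluorophenyl on the aromatic carbon between two ring nitrogen atoms gives, in this assay, no change at the digits printed from compound 3 to compound 4 (within the scatter). Going by these compounds alone, this is the first direct test of this carbon, and it shows that the number stays in the same place when a single chlorine, 1 heavy atom, gives way to a group of 7 heavy atoms that brings in a six-membered aromatic ring, so at least this larger group is accepted here on the unsubstituted phenyl carbamate. No data at hand explain why the swap leaves the number where it is, so the result stands as an observation about these two compounds alone.

The compounds shown leave open whether the fluorine on the new ring matters at all, since a plain phenyl, or a fluorine placed elsewhere on that ring, would be needed to tell. They also leave open how far this tolerance extends to groups of a different kind at the same carbon, such as an amine, a carboxylic acid or a longer alkyl chain.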